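Adding bromo to the phenylsulfanyl group of compound 1

The source may report more compounds than this note shows. Statements on the series, on what has been measured and on what is new or still open speak of the compounds shown alone.

Values measured in a functional assay on MGC-803 cells (Homo sapiens) for cytotoxicity, read by MTT assay, with a stated time of 48 h (a lower number here means a stronger inhibitor, a higher number a weaker inhibitor), for three compounds:
- compound 1 `O=C(CSc1ccccc1)N1N=C(c2cc3ccccc3oc2=O)C[C@@H]1c1ccccc1`: 22800 nM
- compound 2 `CC1=NN(C(=O)CSc2ccccc2)[C@@H](c2cc(Br)cc(Br)c2O)C1`: 12700 nM
- compound 3 `O=C(CSCc1ccco1)N1N=C(c2cc3ccccc3oc2=O)C[C@@H]1c1ccccc1C(F)(F)F`: 15700 nM

Compound 1 lies within the scatter of both compound 2 and compound 3, so these values set no order among the three. Compound 4 `O=C(CSc1ccc(Br)cc1)N1N=C(c2cc3ccccc3oc2=O)C[C@@H]1c1ccccc1` remains unmeasured. It turns the phenylsulfanyl of compound 1 into (4-bromophenyl)sulfanyl, with bromo in place of hydrogen on an aromatic carbon. Going by the values given here, no measured pair isolates this change. In this assay a step no larger than the scatter is therefore expected, leaning slightly towards a lower number. The estimated step is a 1.4-fold lower number from compound 1 to compound 4 (0.15 log units; within the scatter), which stays within the scatter. For compound 4 the estimate is 16000 nM, with an expected range from 6000 nM to 40000 nM.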

Compound 4, half-maximal inhibitory concentration: 16800 nM
Compound 4: middle estimate off by 1.1-fold (0.02 log units), on the low side; the range from low to high includes it.
By their numbers in this assay, from the lowest: compounds 2, 3, 4 and 1 (each within the scatter of the next).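

In this assay the only single-place comparison shown puts bromo in place of hydrogen on an aromatic carbon, para to a large group, and gives a 1.4-fold lower number from compound 1 to compound 4 (0.13 log units; within the scatter) at the phenylsulfanyl group of the shared core. The change to (4-bromophenyl)sulfanyl is therefore tolerated here, with no readable shift in this assay. Nothing measured here explains the step.

As far as these compounds go, whether an amine or a carboxylic acid in the same place would move the number remains open. So does whether bromo elsewhere on this ring would behave alike.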